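A few compounds are considered here, and "the series" means these few. Any claim that something is new, unique, unknown or untested is made for them only; others in the source may bear on it.

Working notes on the series.

Compound 1 `c1ccc(Oc2ccc3c(NCCCNCc4ccco4)ccnc3c2)cc1` is measured in a physicochemical assay for acid dissociation, where compound 1 gives 9.28. Compound 2 `COc1cccc(CNCCCNc2ccnc3cc(Oc4ccccc4)ccc23)c1O` gives 9.28 in this assay, and compound 3 `COc1cccc(CNCCCNc2ccnc3cc(-c4cccc5ccccc45)ccc23)c1O` gives 9.47. Compound 1 thus stands level with compound 2 at the digits shown, the two together the lowest of the three numbers; its nearest neighbour is compound 2, and the furthest is compound 3, which lies within the scatter of it all the same.

Two steps are on record. From compound 1 to compound 2 the change is no change at the digits printed from compound 1 to compound 2 (within the scatter), for 2-hydroxy-3-methoxyphenyl in place of furan-2-yl on a saturated chain carbon bound to an amine nitrogen. From compound 2 to compound 3 the change is a number 0.19 log units higher from compound 2 to compound 3 (within the scatter), for naphthalen-1-yl in place of phenoxy on an aromatic carbon.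

Compound 4 `CCC(CC)c1ccc2c(NCCCNCc3ccco3)ccnc2c1` is not yet measured. It differs from compound 1 in this way: pentan-3-yl in place of phenoxy on an aromatic carbon. Within the data shown here, of the two steps, only the one from compound 2 to compound 3 bears on it, as it also replaces phenoxy on an aromatic carbon of the shared core, and that step stayed within the scatter. Among the measured compounds shown here, no step here moved this assay beyond the scatter, so no step beyond the scatter is expected for compound 4 either. Compound 4 is therefore expected to give 9.3 in this assay, between 9 and 9.65, which is a step of a number 0.02 log units higher from compound 1 to compound 4 (within the scatter) from the measured value.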

Compound 4, acid dissociation constant: 9.47
Compound 4: middle estimate off by 0.17 log units, on the low side; the range from low to high includes it.
By their numbers in this assay, from the lowest: compounds 1, 2, 3 and 4 (each within the scatter of the next).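

In this assay, the exchange of phenoxy for pentan-3-yl on an aromatic carbon of the shared core gives a number 0.19 log units higher from compound 1 to compound 4 (within the scatter), so a group with no ring and no hydrogen-bond acceptor leaves the read-out within the scatter at this position. The earlier step at this place, a number 0.19 log units higher from compound 2 to compound 3 (within the scatter), brought in naphthalen-1-yl, which keeps an aromatic ring, and it was read with 2-hydroxy-3-methoxyphenyl on the chain; the new step extends the same within-scatter outcome to a saturated branched group and to the furan-2-yl side of the series. Nothing at hand accounts for this outcome or ties it to any feature of the groups involved.

Still open is whether this position stays within the scatter when it carries a group of another kind, such as a dimethylamino group or a carboxylic acid, since every group shown there is built of carbon alone or of carbon with an ether oxygen. The compounds shown also all keep the same chain between the two amine nitrogens, so a longer chain there remains an open question for this read-out.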